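This account rests on a few compounds, and the source may have more. Where it says the series, first, only, none or still open, it means among the compounds named here.

Measured compounds:
- compound 1 `N#Cc1cccc(S(=O)(=O)c2ccc3c(c2)CCC[C@H]3C=N)c1` — 0.501 nM
- compound 2 `NC[C@@H]1CCCc2cc(S(=O)(=O)c3c[nH]c4ccccc34)ccc21` — 0.0501 nM
- compound 3 `CN(C[C@@H]1CCCc2cc(S(=O)(=O)c3cccc(F)c3)ccc21)S(N)(=O)=O` — 3.98 nM

In an assay on isolated protein for displacement of a labelled ligand from 5-hydroxytryptamine receptor 6 (Homo sapiens) (on this read-out lower numbers stand for stronger inhibition and higher numbers for weaker inhibition), compound 3 stands highest of the three numbers; both gaps lie beyond the usual scatter, with compound 1 nearer and compound 2 furthest away. Compound 3 thus carries the weakest displacement shown so far in this set.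

Compound 4 `O=S(=O)(c1cccc(F)c1)c1ccc2c(c1)CCC[C@H]2CN1CCCS1(=O)=O` is the untested neighbour of compound 3. The change is a group of 7 heavy atoms (3 carbon, 1 nitrogen, 2 oxygen, 1 sulfur; one five-membered non-aromatic ring with 2 hetero atoms) in place of a group of 6 heavy atoms (1 carbon, 2 nitrogen, 2 oxygen, 1 sulfur; no ring), on a saturated chain carbon bound to a saturated ring carbon. Going by the values given here, no pair of measured compounds differing only in this way exists here, so there is no measured step to lean on; the only guidance is that the three measured compounds span a wide range with different substituents on the same chain carbon, and that the ring closure removes the donor without adding a charge. The expectation for the step from compound 3 to compound 4 in this assay is a 1.6-fold higher number from compound 3 to compound 4 (0.20 log units; within the scatter), a shift toward a somewhat higher number, of modest size and possibly within the scatter. On that basis compound 4 is estimated at 6.3 nM, with a range from 1.6 nM to 25 nM.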

Compound 4, inhibition constant: 31.6 nM
Compound 4: the middle estimate sits 5.0-fold (0.70 log units) below what was measured, outside the stated range (above it).
By their numbers in this assay, from the lowest: compound 2; then compound 1; then compound 3; then compound 4.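

In this assay, putting the five-membered non-aromatic ring with 2 hetero atoms in place of methyl(sulfamoyl)amino, on a saturated chain carbon bound to a saturated ring carbon, gives a 7.9-fold higher number from compound 3 to compound 4 (0.90 log units; beyond the scatter). Going by these compounds alone, this is the first measured step at this position, and it shows that the read-out responds to this exchange even though the hydrogen-bond acceptor count and the net charge stay as they were and only the hydrogen-bond donor is lost. No measured property of these compounds bears on the size or direction of this step.

Whether the loss of the donor or the presence of the ring accounts for the step remains open, since this single pair changes both at once. A methyl(methylsulfonyl)amino group on the same chain carbon, open-chain and without that donor, would bear directly on this question.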